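This account rests on a few compounds, and the source may have more. Where it says the series, first, only, none or still open, it means among the compounds named here.

Compound 1 `O=C(Nc1ccc(Cl)cc1)C1(c2ccc3c(n2)CCN3c2ccccn2)CCC1` gives 2.3 nM in an assay on HeLa cells for inhibition of Indoleamine 2,3-dioxygenase 1 (Homo sapiens) (a lower number here means a stronger inhibitor, a higher number a weaker inhibitor), the lowest of the two numbers recorded so far. Compound 2 `O=C(NCc1ccc2c(c1)CCN2C(=O)c1cccc(Cl)c1)c1ccc(Cl)cc1` gives 90 nM in this assay, a gap from compound 1 that lies beyond the usual scatter. Compound 3 `Cc1nccc(N2CCc3nc(C4(C(=O)Nc5ccc(Cl)cc5)CCC4)ccc32)n1` differs from compound 1 in one place: 2-methylpyrimidin-4-yl in place of pyridin-2-yl on a nitrogen on an aromatic ring in a ring. Within the data shown here, no measured pair shows this change, so the expected step of a 1.5-fold higher number from compound 1 to compound 3 (0.18 log units; within the scatter) is small, a modest weakening or nothing beyond the scatter. Compound 3 is therefore estimated at 3.5 nM, with a range from 1.2 nM to 12 nM.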

Compound 3, half-maximal inhibitory concentration: 12.5 nM
For compound 3 the middle estimate is 3.6-fold (0.55 log units) below the measured one; measured number above the stated range.
By their numbers in this assay, from the lowest: compound 1; then compound 3; then compound 2.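

On the nitrogen of the five-membered non-aromatic ring, 2-methylpyrimidin-4-yl in place of pyridin-2-yl gives a 5.4-fold higher number from compound 1 to compound 3 (0.74 log units; beyond the scatter) in this assay. This shows that the number at this position depends on which six-membered aromatic ring is attached, even though the step is modest. No measurement here accounts for the weakening. The new group brings both a second ring nitrogen and a methyl, and these compounds cannot separate the two. Plain pyrimidin-4-yl, without the methyl, or phenyl at this position remains an open comparison.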